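This account rests on a few compounds, and the source may have more. Where it says the series, first, only, none or still open, it means among the compounds named here.

Measured in a functional assay on A549 cells (Homo sapiens) for inhibition, read by MTT assay, with a stated time of 72 h; a higher number here means a weaker inhibitor, a lower number a stronger inhibitor:
- Compound 1 `COc1ccc(-c2nnc(SCCCN3CCN(c4nc5ccccc5o4)CC3)o2)cc1`: 93500 nM
- Compound 2 `Fc1ccc(-c2nnc(SCCCN3CCN(c4nc5ccccc5o4)CC3)o2)cc1`: 75700 nM
- Compound 3 `CC(C)(C)Oc1ccc(-c2nnc(SCCCN3CCN(c4nc5ccccc5o4)CC3)o2)cc1`: 263000 nM

Compound 3 has the highest number of the three and is the weakest inhibitor of the set in this assay. Compound 4 `Oc1ccc(-c2nnc(SCCCN3CCN(c4nc5ccccc5o4)CC3)o2)cc1` differs from it in one place: hydrogen in place of tert-butyl on an oxygen on an aromatic ring. This puts hydrogen in place of tert-butyl on an oxygen on an aromatic ring, turning 4-(tert-butoxy)phenyl into 4-hydroxyphenyl.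

Within the data shown here, no measured step makes this exact change, but two bear on it from the other direction. Tert-butyl in place of methyl on that oxygen gave a 2.8-fold higher number from compound 1 to compound 3 (0.45 log units; beyond the scatter), and tert-butoxy in place of fluoro gave a 3.5-fold higher number from compound 2 to compound 3 (0.54 log units; beyond the scatter). Fluoro in place of methoxy gave only a 1.2-fold lower number from compound 1 to compound 2 (0.09 log units; within the scatter). Removing the tert-butyl is therefore expected to give a modest move towards a lower number, bringing compound 4 close to compound 1 at 93500 nM. The expected change is a 2.9-fold lower number from compound 3 to compound 4 (0.47 log units; beyond the scatter). Compound 4 is estimated at 90000 nM, with an expected range of 35000 nM to 220000 nM.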

Compound 4, half-maximal inhibitory concentration: 181000 nM
Compound 4: middle estimate off by 2.0-fold (0.30 log units), on the low side, within the range that was stated.
By their numbers in this assay, from the lowest: compounds 2, 1, 4 and 3 (each within the scatter of the next, the first and the last beyond it).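

In this assay hydrogen on this oxygen could not be told apart from either alkyl group, with a 1.5-fold lower number from compound 3 to compound 4 (0.16 log units; within the scatter) on loss of tert-butyl and a 1.9-fold higher number from compound 1 to compound 4 (0.29 log units; within the scatter) on loss of methyl, even though those two ethers differ from each other beyond the scatter. Hydroxy in place of fluoro on the aromatic carbon is a clearer change, at a 2.4-fold higher number from compound 2 to compound 4 (0.38 log units; beyond the scatter) and so hydroxy, like tert-butoxy, stands on the higher-number side of fluoro, while methoxy does not. No measurement is available to explain these results.

The compounds shown leave open whether an amine or a carboxylic acid on this aromatic carbon would read differently from fluoro. They also leave open whether a longer chain on the oxygen, such as n-butyl, would fall nearer to methyl or to tert-butyl.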